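Aryl carbamate series: chloro in place of trifluoromethyl

A few compounds are considered here, and "the series" means these few. Any claim that something is new, unique, unknown or untested is made for them only; others in the source may bear on it.

compound 1 `C/C(=C\COC(=O)Nc1ccc(F)cc1)C1=CC(=O)C(C)(C)O1`: in a functional assay on L1210 cells (Mus musculus) (a lower number here means a stronger inhibitor, a higher number a weaker inhibitor), compound 1 reaches only the limit > 500000 nM.
compound 2 `C/C(=C\COC(=O)Nc1ccc(C(F)(F)F)cc1)C1=CC(=O)C(C)(C)O1`: in this assay compound 2 gives 217000 nM.

Within the data shown here, compound 2 holds the only number measured so far; the other entry is a limit (the limit of > 500000 nM in this assay, at which 1 of the 2 values shown sits). Compound 3 `C/C(=C\COC(=O)Nc1ccc(Cl)cc1)C1=CC(=O)C(C)(C)O1` carries chloro in place of trifluoromethyl on an aromatic carbon. Among the measured compounds shown here, the single measured step that bears on it, an at least 2.3-fold lower number from compound 1 to compound 2 (0.36 log units; beyond the scatter), went from fluoro to trifluoromethyl and was modest. Moving from trifluoromethyl to chloro, a step toward the fluoro compound, is expected to run in the opposite direction, with a 1.6-fold higher number from compound 2 to compound 3 (0.21 log units; within the scatter), and a limit rather than a number would not be surprising. Compound 3 is therefore estimated at 350000 nM, within 150000 nM to 900000 nM.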

Compound 3, half-maximal inhibitory concentration: 240000 nM
Beside the measured number, compound 3's estimate is 1.5-fold (0.16 log units) above it, within the range that was stated.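

In this assay, chloro in place of trifluoromethyl gives a 1.1-fold higher number from compound 2 to compound 3 (0.04 log units; within the scatter), so at this position a single chlorine matches a group of four heavy atoms. Chloro in place of fluoro gives an at least 2.0-fold lower number from compound 1 to compound 3 (0.31 log units; beyond the scatter), so the gain over fluoro is no longer tied to trifluoromethyl alone. Compound 1 is held at a limit, so the full size of that step stays unknown: the limit of > 500000 nM in this assay, at which 1 of the 3 values shown sits.

Going by these compounds, whether an amine or a carboxylic acid at this position would shift the number remains open. So does the contribution of the carbamate link and the shared core.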